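From Phenyl to 4-Nitrophenyl: Expecting Little Change

A few compounds are considered here, and "the series" means these few. Any claim that something is new, unique, unknown or untested is made for them only; others in the source may bear on it.

In a functional assay on UACC-62 cells (Homo sapiens) for cytotoxicity, read by sulforhodamine B assay (on this read-out higher numbers stand for weaker inhibition of growth and lower numbers for stronger inhibition of growth), compound 1 `CC1=CC[C@@H]([C@@](C)(O)CCCC(C)(C)NC(=S)N/N=C\c2ccccc2)CC1` gives 12700 nM. Compound 2 `CC1=CC[C@@H]([C@@](C)(O)CCCC(C)(C)NC(=S)N/N=C\c2ccc(C)cc2)CC1` gives 11600 nM, and compound 3 `CC1=CC[C@@H]([C@@](C)(O)CCCC(C)(C)NC(=S)N/N=C\c2cccc([N+](=O)[O-])c2)CC1` gives 7840 nM. Compound 1 therefore cannot be told apart from either of them. Compound 4 `CC1=CC[C@@H]([C@@](C)(O)CCCC(C)(C)NC(=S)N/N=C\c2ccc([N+](=O)[O-])cc2)CC1` has not yet been measured. It turns the phenyl of compound 1 into 4-nitrophenyl, with nitro para to a large group: nitro in place of hydrogen on an aromatic carbon. The closest guide is the change to 3-nitrophenyl, a 1.6-fold lower number from compound 1 to compound 3 (0.21 log units; within the scatter). The methyl change gives a 1.1-fold lower number from compound 1 to compound 2 (0.04 log units; within the scatter). Both stay within the scatter, so no step beyond it is expected in this assay. The expected step is a 1.4-fold lower number from compound 1 to compound 4 (0.15 log units; within the scatter). For compound 4 the estimated value is 8900 nM, with an expected range from 4500 nM to 16000 nM.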

Compound 4, concentration for 50% growth inhibition: 20800 nM
Estimate against measurement, compound 4: 2.3-fold (0.37 log units) below; the whole stated range lies below it.
By their numbers in this assay, from the lowest: compounds 3, 2, 1 and 4 (each within the scatter of the next, the first and the last beyond it).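

In this assay, among these compounds, the place of the nitro on the ring counts for more than its presence: going from the 3-nitrophenyl to the 4-nitrophenyl gives a 2.7-fold higher number from compound 3 to compound 4 (0.42 log units; beyond the scatter) and is the only step here beyond the scatter. Nitro para to a large group gives a 1.6-fold higher number from compound 1 to compound 4 (0.21 log units; within the scatter) when it replaces hydrogen and a 1.8-fold higher number from compound 2 to compound 4 (0.25 log units; within the scatter) when it replaces methyl, so compound 4 cannot be told apart from either parent. No measurement shown here explains why the two nitro placements differ. The compounds shown leave open what an amine or a carboxylic acid would do at these ring places.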